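Benzylthio phthalonitrile to isobutyl chain: a single swap

A few compounds are considered here, and "the series" means these few. Any claim that something is new, unique, unknown or untested is made for them only; others in the source may bear on it.

Compound 1 `N#Cc1ccc(SCc2ccccc2)cc1C#N` gives 9020 nM in an assay on microsomes for inhibition of Amine oxidase [flavin-containing] A (Homo sapiens), read by fluorescence and spectrophotometry, with a stated time of 20 min; a higher number here means a weaker inhibitor, a lower number a stronger inhibitor.
Compound 2 `N#Cc1ccc(Sc2ccc(Br)cc2)cc1C#N` gives 19000 nM in this assay.

Of the two compounds measured in this assay, compound 1 holds the lower number; compound 2 sits above it by a margin beyond the usual scatter of this measurement. Compound 3 `CC(C)CCSc1ccc(C#N)c(C#N)c1` has not yet been measured in this assay. It keeps the shared core of compound 1 and changes one place: isobutyl in place of phenyl on a saturated chain carbon bound to a sulfur. Within the data shown here, no measured pair shows what this kind of change does, so the direction of the step is uncertain. The aromatic group is traded for a branched chain without any ring, and in the absence of a comparable step the expectation is a modest weakening at most, close to the scatter. The step from compound 1 to compound 3 in this assay is expected to be about a 1.7-fold higher number from compound 1 to compound 3 (0.22 log units; within the scatter). Compound 3 is therefore estimated at 15000 nM, with a range from 5000 nM to 45000 nM.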

Compound 3, half-maximal inhibitory concentration: 1450 nM
Compound 3: middle estimate off by 10-fold (1.01 log units), on the high side; the whole stated range lies above it.
By their numbers in this assay, from the lowest: compound 3; then compound 1; then compound 2.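

In this assay, isobutyl in place of phenyl on a saturated chain carbon bound to a sulfur gives a 6.2-fold lower number from compound 1 to compound 3 (0.79 log units; beyond the scatter) and so moves the number beyond the scatter. At this place, then, the aromatic ring is not needed for inhibition, and a branched chain with no ring gives the stronger inhibitor of this pair. Nothing at hand explains why this swap lowers the number.

The compounds shown leave open whether the lower number comes from the branching or simply from losing the ring, a question that a cyclohexyl group or a straight pentyl chain in the same place would address. They also do not show how a longer branched chain, or an amine carried on the chain, would behave in this assay.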